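A Side Chain Added to Compound 1

This account rests on a few compounds, and the source may have more. Where it says the series, first, only, none or still open, it means among the compounds named here.

The series rests on the core of compound 1 `O=C(CN(c1nc(Cl)nc2[nH]cnc12)C1CC1)NCC(=O)OCc1ccccc1`, which in a functional assay on the whole organism (Tail, strain ICR) with Mus musculus as the target, in the tail flick test, with a stated time of 90 min, at a dose of 25 umol/kg by the oral route (a lower number here means a weaker effect, a higher number a stronger effect of the compound at the dose given), gives 27.2%. Compound 2 `O=C(O)CNC(=O)CN(c1nc(Cl)nc2[nH]cnc12)C1CC1` gives 32.3% in this assay, and compound 3 `O=C(CN(c1ncnc2c1ncn2C1CCCCO1)C1CC1)N[C@@H](CO)C(=O)OCc1ccccc1` gives 32.2% in this assay. Compound 1 has the lowest of the three numbers, but its gaps to compound 3 and to compound 2 are both within the scatter, so the three cannot be ordered. Going by the values given here, the only single-point step, a number 5.1 percentage points higher from compound 1 to compound 2 (within the scatter), is within the scatter as well.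

Compound 4 `CSCC[C@H](NC(=O)CN(c1nc(Cl)nc2[nH]cnc12)C1CC1)C(=O)OCc1ccccc1` differs from compound 1 in one place: 2-(methylsulfanyl)ethyl in place of hydrogen on a saturated chain carbon bound to an amide-type nitrogen and a carbonyl carbon. Among the compounds with values here, no measured step changes that site of the chain alone; compound 3 carries a different group there and a different core, so its value cannot be set against compound 1 as a step. Within the data shown here, the one known step, a number 5.1 percentage points higher from compound 1 to compound 2 (within the scatter), touches another part of the molecule and stayed within the scatter. For compound 4 the expected step is a number 2.8 percentage points higher from compound 1 to compound 4 (within the scatter), within the scatter. The estimate for compound 4 is 30%, with a range from 15% to 48%.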

Compound 4, a percentage reported as activity, at one dose (the size of the read-out at that dose, not a potency): 44.6%
Compound 4: middle estimate off by 14.6 percentage points, on the low side; the range from low to high includes it.
By their numbers in this assay, from the lowest: compounds 1, 3 and 2 (each within the scatter of the next); then compound 4.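

Placing 2-(methylsulfanyl)ethyl on a saturated chain carbon bound to an amide-type nitrogen and a carbonyl carbon gives, in this assay, a number 17.4 percentage points higher from compound 1 to compound 4 (beyond the scatter), the first step in the series beyond the scatter. The only earlier step, a number 5.1 percentage points higher from compound 1 to compound 2 (within the scatter), touched another part of the molecule, so this chain carbon is the first site shown to shift the read-out at the dose given. No other measurement bears on what lies behind this rise.

From the compounds shown here alone, it remains open whether the sulfur matters or any side chain would serve, which a plain butyl group, a longer chain or an amine on the same carbon could test. Also open, going by these compounds, is whether the rise persists in the carboxylic acid corresponding to compound 4.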